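The source may report more compounds than this note shows. Statements on the series, on what has been measured and on what is new or still open speak of the compounds shown alone.

Measured compounds:
Compound 1, `COc1ccccc1-c1cccc(S(=O)(=O)N2CCC(N3CCC(C)CC3)CC2)c1`: > 5000 nM
Compound 2, `CC1CCN(C2CCN(S(=O)(=O)c3nccn3C)CC2)CC1`: > 10000 nM
Compound 3, `Cc1cc(C)c(S(=O)(=O)N2CCC(N3CCC(Cc4ccccc4F)CC3)CC2)c(C)c1`: > 5000 nM

All three results come from an ADME assay on HCT-116 cells (Homo sapiens) for cytotoxicity, read by CellTiter-Glo, with a stated time of 72 h; on this read-out lower numbers stand for stronger inhibition and higher numbers for weaker inhibition. For compound 1 the value > 5000 nM is a limit of the assay and not a number. Compound 2 likewise sits at a limit, > 10000 nM. Compound 3 also sits at a limit, > 5000 nM. Two of the values share (the limit of > 5000 nM in this assay, at which 2 of the 3 values shown sit), while the third sits at the limit of > 10000 nM in this assay, at which 1 of the 3 values shown sits. Compound 1 therefore stands where the other two stand, at a limit, and no order among the three can be read from this assay.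

Compound 4, `Cc1cc(C)cc(-c2cccc(S(=O)(=O)N3CCC(N4CCC(C)CC4)CC3)c2)c1`, differs from compound 1 in one place: 3,5-dimethylphenyl in place of 2-methoxyphenyl on an aromatic carbon. For the measured compounds named here, no two measured compounds differ in a single place, so no measured step gives the size of such a change. Because compound 1 sits at > 5000 nM, a limit, and compound 2 and compound 3 also give only limits, the change is expected to leave the read-out where it is. The expected step is a step that the limit leaves unreadable from compound 1 to compound 4, meaning nothing beyond the scatter. Compound 4 is estimated at 10000 nM, with a range from 3000 nM to 40000 nM, and the assay is expected most likely to report only a limit again.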

Compound 4, half-maximal inhibitory concentration: > 5000 nM
Compound 4: only a limit was reported; the forecaster's own chance of this, stated with the estimate: 85%; the middle value lies beyond the limit too.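

Compound 4 gives > 5000 nM as a limit of the assay and not a number. Compound 1 also sits at a limit, so no new step can be read between compound 1 and compound 4. The compounds shown leave open what concentration, if any, reaches half-maximal inhibition in this assay and whether 3,5-dimethylphenyl and 2-methoxyphenyl differ on this read-out.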